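The source may hold more compounds than are shown below. What is called first, only, known or untested is meant among the compounds shown, and "the series" means these compounds.

Measured in a physicochemical assay for solubility, in phosphate buffer; on this read-out higher numbers stand for higher solubility and lower numbers for lower solubility:
- Compound 1 `C[C@H]1CN([C@@H](C)CO)C(=O)c2cccc(NC(=O)c3ccncc3)c2O[C@@H]1CN(C)Cc1ccc(Cl)c(Cl)c1`: 64000 nM
- Compound 2 `C[C@@H]1CN([C@H](C)CO)C(=O)c2cccc(NC(=O)c3ccncc3)c2O[C@@H]1CN(C)Cc1ccc(Oc2ccccc2)cc1`: 86000 nM
- Compound 3 `C[C@@H]1CN([C@H](C)CO)C(=O)c2cccc(NC(=O)c3ccncc3)c2O[C@H]1CN(C)Cc1ccc(Oc2ccccc2)cc1`: 1000 nM

Compound 2, at 86000 nM, stands at the top of these three numbers together with compound 1, at 64000 nM, the two lying within the scatter of each other. Compound 3 sits well apart from both, at 1000 nM.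

Going by the values given here, the one measured step is an 86-fold lower number from compound 2 to compound 3 (1.93 log units; beyond the scatter). That gap can be put down to configuration because of the fact that compounds 2 and 3 differ only in the configuration as drawn.

Compound 4 `C[C@H]1CN([C@@H](C)CO)C(=O)c2cccc(NC(=O)c3ccncc3)c2O[C@@H]1CN(C)Cc1ccc(Oc2ccccc2)cc1` has not yet been measured. Its difference from compound 2 is again purely one of configuration: the two compounds have the same atoms and bonds and differ only in configuration as drawn: 2 of 3 stereo elements differ; a stereocentre at a saturated ring carbon is drawn R in compound 2 and S in compound 4; a stereocentre at a saturated chain carbon is drawn R in compound 2 and S in compound 4. The stereocentre inverted in the measured step is drawn S in compound 2, so neither centre changed here is that one. Among the compounds with values here, no measured step tests either of these two centres alone.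

Within the data shown here, the only guide is therefore an 86-fold lower number from compound 2 to compound 3 (1.93 log units; beyond the scatter), which shows that a change of configuration can shift this assay strongly. A moderate fall is expected, smaller than that step, with wide uncertainty. The estimated step is a 3.4-fold lower number from compound 2 to compound 4 (0.54 log units; beyond the scatter). The estimate for compound 4 is 25000 nM, with an expected range from 2000 nM to 100000 nM.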

Compound 4, solubility: 1000 nM
Estimate against measurement, compound 4: 25-fold (1.40 log units) above; the measured number lies below the stated range.
By their numbers in this assay, from the lowest: compounds 3 and 4 (each within the scatter of the next); then compounds 1 and 2 (each within the scatter of the next).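

In this assay, inverting the ring and chain centres that the earlier step left untouched gives an 86-fold lower number from compound 2 to compound 4 (1.93 log units; beyond the scatter), so a large fall is no longer tied to the single ring centre inverted in an 86-fold lower number from compound 2 to compound 3 (1.93 log units; beyond the scatter). This fall can be put down to configuration alone, since nothing else separates the pair: the fact that compounds 2 and 4 differ only in the configuration as drawn Compounds 3 and 4 are mirror images, and inverting all three centres gives no change at the digits printed from compound 3 to compound 4 (within the scatter), so among these three stereoisomers compound 2 stands apart while the two routes away from it end at the same number.

On these data alone, what stays open is whether the ring centre or the chain centre inverted between compound 2 and compound 4 carries the fall, or whether both are needed, since the two change together in this step. Also open, as far as these compounds go, is whether a compound with a carboxylic acid or a longer chain in place of the phenoxy group would respond to these inversions in the same way.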